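Bromine to two chlorines on the aryl ring

The compounds below may be only part of what the source reports. "The series", "measured", "known", "first", "only" and "open" are said of these compounds alone.

Compound 1 `COC(=O)C1=C(C)N=C(C)/C(=C(\O)OC)C1c1ccccc1OC`: 57.5 nM
Compound 2 `COC(=O)C1=C(C)N=C(C)/C(=C(\O)OC)C1c1cccc(N)c1`: 2000 nM
Compound 3 `COC(=O)C1=C(C)N=C(C)/C(=C(\O)OC)C1c1cccc(Br)c1`: 1.29 nM

In a functional assay (muscle tissue) with Cavia porcellus as the target (a higher number here means that more compound is needed for the effect, a lower number that less compound is needed), compound 3 gives the lowest number of the three, 1.29 nM, so it needs the least compound for the effect. Compound 4 `COC(=O)C1=C(C)N=C(C)/C(=C(\O)OC)C1c1cccc(Cl)c1Cl` shares the core of compound 3 but has 2,3-dichlorophenyl in place of 3-bromophenyl on a saturated ring carbon. For the measured compounds named here, no measured step makes this exact swap, and no measured compound carries chlorine or two groups on the phenyl ring, so the evidence is indirect. Changing the aryl group gave a 45-fold lower number from compound 1 to compound 3 (1.65 log units; beyond the scatter). Replacing amino with bromo gave a 1600-fold lower number from compound 2 to compound 3 (3.19 log units; beyond the scatter). Both steps are large, so changes at this aryl group can clearly move the number a long way. Compound 4 still carries halogen on the phenyl ring, as does compound 3 at 1.29 nM, so a collapse on the scale of the second step is not expected. A modest move toward a higher number is expected, though the data cannot firmly fix its direction. The expected change is a 3.1-fold higher number from compound 3 to compound 4 (0.49 log units; beyond the scatter). For compound 4 the estimated value is 4 nM, with an expected range from 0.8 nM to 20 nM.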

Compound 4, half-maximal effective concentration: 19.1 nM
Estimate against measurement, compound 4: 4.8-fold (0.68 log units) below; the measured number falls inside the stated range.
By their numbers in this assay, from the lowest: compound 3; then compound 4; then compound 1; then compound 2.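

In this assay, replacing 3-bromophenyl with 2,3-dichlorophenyl on the saturated ring carbon gives a large rise (a 15-fold higher number from compound 3 to compound 4 (1.17 log units; beyond the scatter)), so halogen on the phenyl ring does not by itself keep the number as low as that of compound 3. The dichlorinated ring still stays far from the amino-bearing ring (a 100-fold lower number from compound 2 to compound 4 (2.02 log units; beyond the scatter)), and it gives a smaller gain over the 2-methoxyphenyl group (a 3.0-fold lower number from compound 1 to compound 4 (0.48 log units; beyond the scatter)), which places it third from the top of the order by need for compound, with only compound 3 needing less and the gap to the methoxy compound being the smallest of the three new steps. There is no measurement on hand that explains any of these differences.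

This single swap changes the halogen and the number of substituents together, so it cannot say how much of the rise belongs to losing bromine and how much to the added chlorine; 3-chlorophenyl and 2-chlorophenyl would separate the two. As far as these compounds go, how a larger group such as 3-nitrophenyl or 3-trifluoromethylphenyl would compare on this ring carbon also stays open.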